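Swapping a Chloropyridine for Plain Phenyl

A few compounds are considered here, and "the series" means these few. Any claim that something is new, unique, unknown or untested is made for them only; others in the source may bear on it.

Measured compounds:
- compound 1, `Cc1cc(C(=O)O)ccc1CN1CCC[C@H](O[C@H](CO)c2ccnc(Cl)c2)[C@@H]1c1ccccc1`: 50000 nM
- compound 2, `O=C(O)c1ccc(CN2CCC[C@H](O[C@H](CO)c3cc(Cl)cc(Cl)c3)[C@@H]2c2ccccc2)c(C2CC2)c1`: 1800 nM
- compound 3, `Cc1cc(C(=O)O)ccc1CN1CCC[C@H](O[C@H](CO)c2cc(Cl)cc(Cl)c2)[C@@H]1C1CCCCC1`: 65000 nM

In an assay on isolated protein for activation of cGMP-dependent protein kinase 1 (Homo sapiens), read by ADP-Glo, with stated times of 30 min and 2 h, in the presence of a further agent that is not named here (a lower number here means that less compound is needed, a higher number that more compound is needed for the effect), compound 1 gives 50000 nM, the second highest of the three numbers. Compound 3 sits closest to it, with a number that lies within the usual scatter, so the two cannot be told apart. Compound 2 gives 1800 nM, a much lower number, well beyond the scatter. Compound 2 and compound 3 each differ from compound 1 in more than one place, so no single change can be read from them.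

Compound 4, `Cc1cc(C(=O)O)ccc1CN1CCC[C@H](O[C@H](CO)c2ccccc2)[C@@H]1c1ccccc1`, has not yet been measured. It differs from compound 1 in one place: phenyl in place of 2-chloropyridin-4-yl on a saturated chain carbon bound to an oxygen on a saturated carbon and a saturated chain carbon. Going by the values given here, no measured pair shows this change on its own, so the expectation rests on the weak starting point of compound 1 alone. A small step is expected, most likely within the scatter, with no strong reason to favour either direction. Compound 4 is therefore estimated at 40000 nM, in the range 10000 nM to 150000 nM, which means an expected step of a 1.3-fold lower number from compound 1 to compound 4 (0.10 log units; within the scatter).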

Compound 4, half-maximal effective concentration: 25000 nM
Beside the measured number, compound 4's estimate is 1.6-fold (0.20 log units) above it; the measured number falls inside the stated range.
By their numbers in this assay, from the lowest: compound 2; then compounds 4, 1 and 3 (each within the scatter of the next, the first and the last beyond it).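

In this assay the swap of 2-chloropyridin-4-yl for phenyl, on a saturated chain carbon bound to an oxygen on a saturated carbon and a saturated chain carbon, gives a 2.0-fold lower number from compound 1 to compound 4 (0.30 log units; within the scatter) and so leaves the two compounds indistinguishable. Going by these compounds alone, this is the first direct reading of this position: the ring can lose its nitrogen and its chlorine together with no change that stands out from the variation between repeated measurements, although the numbers of both compounds remain high. No further data bear on why this swap has so little effect.

Going by these compounds, the nitrogen and the chlorine left together, so their separate contributions remain unknown, and they could be teased apart with a pyridine ring without chlorine and a phenyl ring carrying chlorine alone. On these data alone, whether this position responds at all to a clearly different group, such as an amine or a carboxylic acid on the ring, also stays open, and the other compounds differ from these two in more than one place, so those comparisons cannot be read.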